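The compounds below may be only part of what the source reports. "The series", "measured", "known", "first", "only" and "open" are said of these compounds alone.

In a toxicity assay on MDCK cells (Canis lupus familiaris) for cytotoxicity, read by CCK-8 assay, with a stated time of 48 h (on this read-out lower numbers stand for higher toxicity in this test and higher numbers for lower toxicity in this test), compound 3 (`N#Cc1ccc(C(=O)NNc2c(Br)cccc2Br)cc1`) gives > 100000 nM as a limit and not a number. Compound 1 (`CCCCOc1ccc(C(=O)NNc2c(Br)cccc2Br)cc1`) gives > 100000 nM as a limit too. Compound 2 (`O=C(NNc1c(Br)cccc1Br)c1ccc(OCC(F)(F)F)cc1`) gives > 100000 nM as a limit as well. The whole set thus rests on one reading, the limit of > 100000 nM in this assay, at which 3 of the 3 values shown sit, and nothing finer. Compound 4 (`O=C(NNc1c(Br)cccc1Br)c1ccccc1`) differs from compound 3 by hydrogen in place of cyano on an aromatic carbon in all. The measured steps at this same place are a step that the two limits leave unreadable from compound 1 to compound 3 and a step that the two limits leave unreadable from compound 2 to compound 3 and neither has a readable size, so in this assay no step beyond the scatter and no direction is expected. The estimated step is a number no higher from compound 3 to compound 4 (the limit leaves the size open) on this basis. Compound 4 is expected at 100000 nM with an estimated range of 40000 nM to 200000 nM in this read-out.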

Compound 4, half-maximal cytotoxic concentration: > 100000 nM
Compound 4: only a limit was reported; the forecaster's own chance of this, stated with the estimate: 85%; the middle value sits exactly at the limit.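

In this assay, going by these compounds alone, compound 4 gives > 100000 nM, a limit and not a number, so no step linking it to compound 1, compound 2 or compound 3 can be read. The compounds shown leave open whether any of these replacements changes the half-maximal cytotoxic concentration, as all rest on one reading: the limit of > 100000 nM in this assay, at which 4 of the 4 values shown sit.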